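The source may report more compounds than this note shows. Statements on the series, on what has been measured and on what is new or still open speak of the compounds shown alone.

Measured compounds:
compound 1, `COc1ccc(/C=C/C2CC(=O)C=CO2)cc1` — 149 uM
compound 2, `COc1ccc(C2CC(=O)C=CO2)cc1` — 193 uM
compound 3, `COc1ccc(-c2cc(=O)cco2)cc1` — > 1230 uM

In a functional assay on NCI-H460 cells (Homo sapiens) for inhibition, read by sulforhodamine B assay, with a stated time of 48 h (on this read-out higher numbers stand for weaker inhibition of growth and lower numbers for stronger inhibition of growth), compound 1 gives 149 uM, and compound 2 gives 193 uM. These two numbers lie within the usual scatter of each other, so neither compound can be set apart from the other on this evidence; compound 2 simply sits alongside compound 1 among the two numbers measured. For compound 3 the assay reports only a limit, > 1230 uM, and not a number; this is the limit of > 1230 uM in this assay, at which 1 of the 3 values shown sits. No pair among these three differs in only one place, so no measured step is available.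

Compound 4, `COc1ccc(C2CC(=O)C(Br)=CO2)cc1`, has not yet been measured. It differs from compound 2 by bromo in place of hydrogen on a double-bonded ring carbon. Going by the values given here, with no step of the same kind measured here, the size and direction of the change can only be guessed; the expectation is a step of modest size, a 1.6-fold lower number from compound 2 to compound 4 (0.21 log units; within the scatter), in the direction of stronger inhibition of growth, though a result within the scatter would not surprise. For compound 4 the estimated value in this assay is 120 uM, within a range from 40 uM to 400 uM.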

Compound 4, concentration for growth inhibition (reported as GI): 118 uM
Estimate against measurement, compound 4: 1.0-fold (0.01 log units) above; low and high end bracket the measured number.
By their numbers in this assay, from the lowest: compounds 4, 1 and 2 (each within the scatter of the next). At a limit, above all of these: compound 3.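

In this assay, bromo in place of hydrogen on the double-bonded ring carbon gives a 1.6-fold lower number from compound 2 to compound 4 (0.21 log units; within the scatter). This is the only measured step among these compounds that differ in one place, and it shows that a bromine atom can replace hydrogen at this position, two ring bonds from the ring oxygen, without a difference that can be told apart from the usual scatter of repeated measurements. The data shown offer no measured explanation for this result.

On these data alone, how an amine or a carboxylic acid at the same ring carbon would read remains open, since a single small step says little about groups of other kinds. As far as these compounds go, it is also open whether bromo in the same place on the core of compound 1 would give a step of similar size.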